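Purine series: effect of removing a chloro substituent

The source may hold more compounds than are shown below. What is called first, only, known or untested is meant among the compounds shown, and "the series" means these compounds.

Measured so far:
compound 1, `ClCc1ccc(Cn2cnc3c(Cl)ncnc32)cc1`: 7410 nM
compound 2, `ClCc1ccccc1Cn1cnc2c(Cl)nc(Cl)nc21`: 4570 nM

In a functional assay on U-251 cells (Homo sapiens) for cytotoxicity, read by sulforhodamine B assay, with a stated time of 48 h (a higher number here means that more compound is tolerated, a lower number that less compound is tolerated), compound 2 gives 4570 nM and compound 1 gives 7410 nM; these two numbers lie within the usual scatter of each other, so neither compound can be set apart from the other on this read-out. Going by the values given here, no pair among the measured compounds differs in only one place, so no single-change step is available to calibrate the next move.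

Compound 3, `ClCc1ccccc1Cn1cnc2c(Cl)ncnc21`, is the next compound to be measured in this assay. It arises from compound 2 by the change (hydrogen in place of chloro on an aromatic carbon). Among the compounds with values here, the only comparison available, between compound 1 and compound 2, shows that a compound carrying one chloro on the core and a compound carrying two give numbers within the scatter, so the step from compound 2 to compound 3 is expected to be small, if anything upward, and probably not beyond the scatter: a 1.5-fold higher number from compound 2 to compound 3 (0.19 log units; within the scatter). Compound 3 is expected to give about 7000 nM, in a range from 2500 nM to 22000 nM.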

Compound 3, concentration lethal to 50% of the cells: 61700 nM
Estimate against measurement, compound 3: 8.8-fold (0.95 log units) below, outside the stated range (above it).
By their numbers in this assay, from the lowest: compounds 2 and 1 (each within the scatter of the next); then compound 3.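

In this assay, going by these compounds alone, the chloro on the aromatic carbon between two ring nitrogen atoms turns out to carry weight: hydrogen in place of chloro gives a 14-fold higher number from compound 2 to compound 3 (1.13 log units; beyond the scatter) and is the first single-place step readable. With this step, compound 2 needs far less compound than compound 3 to reach the lethal read-out, so this position is not a silent one, as the earlier pair of values might have suggested. Nothing at hand accounts for the size of this step.

The compounds shown leave open whether an amine or a methoxy group on this carbon would stay near compound 2 or near compound 3. They also leave open whether the same step would appear on the chloromethyl arrangement of compound 1.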